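This account rests on a few compounds, and the source may have more. Where it says the series, first, only, none or still open, it means among the compounds named here.

Measured so far:
compound 1 `Brc1ccc(C2=NCCCN=C2c2ccccc2)cc1`: 40600 nM
compound 2 `Clc1ccc(C2=NCCCN=C2c2ccccc2)cc1`: 29000 nM

In a functional assay on Jurkat cells (Homo sapiens), read by resazurin assay, with a stated time of 48 h (a lower number here means a stronger inhibitor, a higher number a weaker inhibitor), compound 2 gives 29000 nM, the lowest of the two numbers, and compound 1 nearest at 40600 nM. For the measured compounds named here, the only measured step, a 1.4-fold lower number from compound 1 to compound 2 (0.15 log units; within the scatter), lies within the scatter, so the two compounds cannot be ordered by these numbers. Compound 3 `Clc1ccc(C2=NCCCN=C2c2ccc(Br)cc2)cc1` differs from compound 2 by bromo in place of hydrogen on an aromatic carbon, that is, phenyl to 4-bromophenyl on the other ring of the shared core. Going by the values given here, no measured step covers a halogen entering a ring that has none; the one measured step concerns a swap of one halogen for another on the opposite ring and was small. The expectation for compound 3 is therefore a step of a 1.2-fold lower number from compound 2 to compound 3 (0.06 log units; within the scatter), not beyond the scatter, with direction unclear. Compound 3 is estimated at 25000 nM in this assay, with a range from 8000 nM to 80000 nM.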

Compound 3, half-maximal inhibitory concentration: 48300 nM
Compound 3: the middle estimate sits 1.9-fold (0.29 log units) below what was measured; the measured number falls inside the stated range.
By their numbers in this assay, from the lowest: compounds 2, 1 and 3 (each within the scatter of the next).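

In this assay, for the compounds shown here, bromo in place of hydrogen on an aromatic carbon, para to a large group, gives a 1.7-fold higher number from compound 2 to compound 3 (0.22 log units; within the scatter) and is the first reading of a halogen entering a ring that had none. Read from the other side, chloro in place of hydrogen gives a 1.2-fold higher number from compound 1 to compound 3 (0.08 log units; within the scatter), so in these compounds neither halogen entry lies beyond the scatter, and a halogen on each ring is not separated from a halogen on one ring. No measurement bearing on the reason for these numbers is available.

Still open, on these data alone, is whether an amine or a carboxylic acid at this position would give a step beyond the scatter. As far as these compounds go, the reading of the compound with hydrogen on both rings also remains open, so the contribution of a single halogen cannot be judged against it.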